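Hydroxypyridinyl in place of furanyl on the amide carbonyl

This account rests on a few compounds, and the source may have more. Where it says the series, first, only, none or still open, it means among the compounds named here.

compound 1 `Cc1ccc2c(c1C)C(=O)N(Cc1cc(Br)ccc1NC(=O)c1ccccn1)C2=O` — > 100000 nM
compound 2 `O=C(Nc1ccc(Cl)cc1CN1C(=O)c2ccccc2C1=O)c1ccco1` — 2300 nM
compound 3 `COc1ccc2c(c1OC)C(=O)N(Cc1cc(Cl)ccc1NC(=O)c1ccccn1)C2=O` — > 100000 nM

Among the compounds with values here, in an assay on CHO cells for positive allosteric modulation of metabotropic glutamate receptor 5 (Homo sapiens), read by FLIPR (on this read-out lower numbers stand for an effect already at smaller amounts and higher numbers for an effect only at larger amounts of compound), compound 2 gives 2300 nM, the only number among the three values shown. For compound 1 the assay reports only a limit, > 100000 nM. For compound 3 it likewise reports only a limit, > 100000 nM. Two of the three values thus sit at the limit of > 100000 nM in this assay, at which 2 of the 3 values shown sit. Compound 4 `O=C(Nc1ccc(Cl)cc1CN1C(=O)c2ccccc2C1=O)c1ncccc1O` differs from compound 2 by 3-hydroxypyridin-2-yl in place of furan-2-yl on a carbonyl carbon. Within the data shown here, no step between two measured compounds is known, so the effect of this change can only be expected: a modest step from compound 2 to compound 4 toward larger amounts, a 2.2-fold higher number from compound 2 to compound 4 (0.34 log units; beyond the scatter), is estimated in this assay. Compound 4 is expected at 5000 nM, between 1000 nM and 50000 nM.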

Compound 4, half-maximal effective concentration: 260 nM
For compound 4 the middle estimate is 19-fold (1.28 log units) above the measured one, outside the stated range (below it).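

In this assay, the position on the carbonyl carbon whose other neighbour is the amide-type nitrogen proves responsive to the ring placed there: 3-hydroxypyridin-2-yl in place of furan-2-yl gives an 8.8-fold lower number from compound 2 to compound 4 (0.95 log units; beyond the scatter) on an unchanged core. This is the first step shown at this position, and it shows that the furan-2-yl ring can be replaced by a six-membered aromatic ring with a gain. Nothing shown explains this gain.

As far as these compounds go, whether the hydroxy group or the ring nitrogen carries the step stays open. So does what a 3-methoxypyridin-2-yl or 3-aminopyridin-2-yl group would give at this position.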